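Chloro in Place of Trifluoromethyl on Compound 1

A few compounds are considered here, and "the series" means these few. Any claim that something is new, unique, unknown or untested is made for them only; others in the source may bear on it.

Two compounds have been measured so far in an assay on isolated protein for inhibition of histone deacetylase 4 (Homo sapiens), with a stated time of 1 h; on this read-out lower numbers stand for stronger inhibition and higher numbers for weaker inhibition:
compound 1, `O=C(COc1ccc2cc(/C=C3/SC(=O)NC3=O)ccc2c1)Nc1cccc(C(F)(F)F)c1`: 2500 nM
compound 2, `O=C(CN1C(=O)S/C(=C/c2ccccn2)C1=O)Nc1nc2ccccc2s1`: 9300 nM

Of these two numbers, compound 1 gives the lower one, and the value of compound 2 stands beyond the usual scatter above it. The two compounds differ in more than one place, so their pair says nothing about any single change.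

Compound 3, `O=C(COc1ccc2cc(/C=C3/SC(=O)NC3=O)ccc2c1)Nc1cccc(Cl)c1`, has not yet been measured in this assay. It differs from compound 1 in one place: chloro in place of trifluoromethyl on an aromatic carbon. Going by the values given here, no measured pair shows what this exchange does on the shared core, so the expectation rests on compound 1 alone. The group that leaves and the group that enters are both small, and both carry no hydrogen-bond donors or acceptors. The step is expected to be small, a 1.2-fold higher number from compound 1 to compound 3 (0.08 log units; within the scatter), and to fall within the scatter, in no firm direction. Compound 3 is therefore estimated at 3000 nM, with a range from 1000 nM to 9000 nM.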

Compound 3, half-maximal inhibitory concentration: 3800 nM
For compound 3 the middle estimate is 1.3-fold (0.10 log units) below the measured one; measured number inside the range.
By their numbers in this assay, from the lowest: compounds 1 and 3 (each within the scatter of the next); then compound 2.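

In this assay, going by these compounds alone, the exchange of trifluoromethyl for chloro on this aromatic carbon gives a 1.5-fold higher number from compound 1 to compound 3 (0.18 log units; within the scatter) on the shared core, and this is the first pair in the set that isolates a single change. At this position, then, the 3-(trifluoromethyl)phenyl and 3-chlorophenyl forms cannot be told apart by this read-out, so the exchange neither gains nor loses anything that can be distinguished from repeat variation. Nothing available bears on why the two groups read alike, and no measured property of either group is at hand.

The compounds shown leave open whether this carbon accepts groups of a different kind, since an amine, a carboxylic acid or a hydroxyl in the same place might move the number in this assay well beyond what these two groups do. They also leave open whether the same exchange would read alike on the core of compound 2, which carries a different aromatic group on its amide and differs from compound 1 in more than one place.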